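Swapping One Aromatic Group on a Weak Inhibitor

A few compounds are considered here, and "the series" means these few. Any claim that something is new, unique, unknown or untested is made for them only; others in the source may bear on it.

Of the compounds shown here, two have so far been tested in an ADME assay on HUVEC cells (Homo sapiens) for antiproliferative activity, read by MTT assay, with a stated time of 48 h; a lower number here means a stronger inhibitor, a higher number a weaker inhibitor. Compound 1, `N#CC1=C(N)Oc2c(c3nc4ccccc4nc3c3ccccc23)C12C(=O)N(Cc1cnnn1-c1ccc(N)cc1)c1ccccc12`, gives > 50000 nM, which is a limit of this assay and not a number. Compound 2, `N#CC1=C(N)Oc2c(N)cc3nc4ccccc4nc3c2C12C(=O)N(Cc1cnnn1-c1ccccc1Br)c1ccccc12`, gives 34200 nM in this assay. That is the only number shown. For the measured compounds named here, the other value shown sits at a limit of this assay, the one reached by compound 1 (the limit of > 50000 nM in this assay, at which 1 of the 2 values shown sits). Compound 3, `Cc1cc(C)c(-n2nncc2CN2C(=O)C3(C(C#N)=C(N)Oc4c(N)cc5nc6ccccc6nc5c43)c3ccccc32)c(C)c1`, has not yet been measured. It differs from compound 2 in one place: 2,4,6-trimethylphenyl in place of 2-bromophenyl on an aromatic nitrogen. Going by the values given here, no step between two measured compounds is available, so the effect of this change cannot be read off anything already seen. Taking the one number of compound 2 as the anchor, the expected step of a 1.0-fold higher number from compound 2 to compound 3 (0.01 log units; within the scatter) is small, within the usual scatter, in no particular direction. Compound 3 is therefore estimated at 35000 nM in this assay, with a range from 12000 nM to 100000 nM, and a fair chance that only a limit is reported.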

Compound 3, half-maximal inhibitory concentration: > 50000 nM
Compound 3: a limit, no number (the forecaster's own chance of this, stated with the estimate: 40%); middle value at least 1.4-fold (0.15 log units) from the limit.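

In this assay, for the compounds shown here, replacing 2-bromophenyl with 2,4,6-trimethylphenyl on the aromatic nitrogen gives the first step that can be read at this position: an at least 1.4-fold higher number from compound 2 to compound 3 (0.16 log units; that floor lies within the scatter). This step is only a floor, so the real gap could be small or much larger, but nothing here shows that the new group brings the number down. Compound 3 gives a limit and not a number, and it joins compound 1 at the same limit: the limit of > 50000 nM in this assay, at which 2 of the 3 values shown sit.

The compounds shown leave open how an unsubstituted phenyl, or a phenyl carrying a methoxy group or a carboxylic acid, would read at this position. Going by these compounds alone, with only one number among the three values, no trend across the groups at this position can be drawn.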